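The source may report more compounds than this note shows. Statements on the series, on what has been measured and on what is new or still open speak of the compounds shown alone.

In an assay on HEK293 cells for agonist activity at transient receptor potential cation channel subfamily M member 8 (Homo sapiens), read by fluorescence and calcium flux, with a stated time of 15 min (on this read-out lower numbers stand for an effect already at smaller amounts and higher numbers for an effect only at larger amounts of compound), three compounds have been measured. Compound 1 `Cc1ccc(OCC(=O)N(Cc2cccs2)c2cccnc2)cc1` gives 198 nM, compound 2 `CCN(Cc1cccs1)C(=O)COc1ccc(F)cc1` gives 422 nM, and compound 3 `Cc1ccc(OCC(=O)N(Cc2cccs2)C2CCCCC2)cc1` gives 40000 nM. Compound 2 thus holds the second highest of the three numbers: its nearest neighbour is compound 1, whose value lies somewhat lower, and its furthest is compound 3, whose value lies far higher. Going by the values given here, the only change of a single place among the measured compounds is a 200-fold higher number from compound 1 to compound 3 (2.31 log units; beyond the scatter), which concerns the group on the amide-type nitrogen and not the aromatic ring.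

Compound 4 `CCCc1ccc(OCC(=O)N(CC)Cc2cccs2)cc1` differs from compound 2 by propyl in place of fluoro on an aromatic carbon. Among the compounds with values here, no measured step touches this part of the molecule; compound 1 and compound 2 differ from each other in two places at once, so their gap cannot be laid to the aromatic substituent alone. In this assay the step from compound 2 to compound 4 is therefore expected to be small, a 1.3-fold lower number from compound 2 to compound 4 (0.12 log units; within the scatter), with no clear direction beyond the scatter. Compound 4 is accordingly estimated at 320 nM, within a range from 100 nM to 1200 nM.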

Compound 4, half-maximal effective concentration: 1810 nM
For compound 4 the middle estimate is 5.7-fold (0.75 log units) below the measured one; the whole stated range lies below it.
By their numbers in this assay, from the lowest: compound 1; then compound 2; then compound 4; then compound 3.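

In this assay, going by these compounds alone, the aromatic carbon para to a large group, which no earlier single-place step had touched, proves sensitive to this exchange: with propyl in place of fluoro there is a 4.3-fold higher number from compound 2 to compound 4 (0.63 log units; beyond the scatter). Replacing one heavy atom with three on this carbon therefore changes the number beyond the scatter, although the step remains much smaller than a 200-fold higher number from compound 1 to compound 3 (2.31 log units; beyond the scatter), seen on the amide-type nitrogen. Within the data shown here, the data show only that this change has an effect, and nothing available explains why the number rises.

With only fluoro and propyl compared directly at this position, a single step cannot show whether the number follows chain length or depends on the loss of fluoro, and it cannot show how an ethyl chain, a methoxy group, an amine or a carboxylic acid would fall in relation to these two. Going by these compounds, it also remains open whether the same exchange would have a step of similar size and direction on the core of compound 1, which carries pyridin-3-yl on the amide-type nitrogen.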